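The source may hold more compounds than are shown below. What is called first, only, known or untested is meant among the compounds shown, and "the series" means these compounds.

- compound 1 `CCCCCCCC(=O)Oc1cc(C(=O)C2=C3OC(C)(C)[C@@H](CC=C(C)C)C[C@@]34C[C@@H](CC=C(C)C)C(C)(C)[C@H]3CCC(C)(C)O[C@]34OC2=O)ccc1O`: 15300 nM
- compound 2 `CC(=O)Oc1ccc(C(=O)C2=C3OC(C)(C)[C@@H](CC=C(C)C)C[C@@]34C[C@@H](CC=C(C)C)C(C)(C)[C@H]3CCC(C)(C)O[C@]34OC2=O)cc1OC(C)=O`: > 20000 nM, a limit
- compound 3 `CC(C)=CC[C@H]1C[C@]23C[C@@H](CC=C(C)C)C(C)(C)[C@H]4CCC(C)(C)O[C@]42OC(=O)C(C(=O)c2ccc(OC(=O)c4ccc(F)cc4)c(OC(=O)c4ccc(F)cc4)c2)=C3OC1(C)C`: > 20000 nM, a limit

Among the measured compounds shown here, in a functional assay on K562 cells (Homo sapiens) for antiproliferative activity, read by MTT assay, with a stated time of 72 h (on this read-out lower numbers stand for stronger inhibition and higher numbers for weaker inhibition), compound 1 gives 15300 nM, the only true number so far. The other two readings are limits: the limit of > 20000 nM in this assay, at which 2 of the 3 values shown sit.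

Compound 4 `CCCCCC(=O)Oc1cc(C(=O)C2=C3OC(C)(C)[C@@H](CC=C(C)C)C[C@@]34C[C@@H](CC=C(C)C)C(C)(C)[C@H]3CCC(C)(C)O[C@]34OC2=O)ccc1O` differs from compound 1 in one place: hydrogen in place of ethyl on a saturated chain carbon, five bonds along the chain from a carbonyl carbon. For the measured compounds named here, no measured pair shows this change, so no shift beyond the usual scatter is expected in this assay. The expected 1.1-fold lower number from compound 1 to compound 4 (0.04 log units; within the scatter) is correspondingly small. For compound 4 the estimated value is 14000 nM, with an expected range of 7000 nM to 20000 nM.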

Compound 4, half-maximal inhibitory concentration: 13500 nM
Compound 4: the middle estimate sits 1.0-fold (0.02 log units) above what was measured; the measured number falls inside the stated range.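

In this assay, among the compounds shown here, the step is a 1.1-fold lower number from compound 1 to compound 4 (0.05 log units; within the scatter): this is the first measured pair that differs in one place. At this saturated chain carbon, five bonds along the chain from a carbonyl carbon, hydrogen in place of ethyl leaves the number within the scatter, so butyl to ethyl at the chain end gives no readable shift.

On these data alone, whether a longer chain, or a chain carrying an amine or a carboxylic acid, would move the number beyond the scatter stays open. Only compound 1 and compound 4 give true numbers here, and the rest of the series is bounded by a limit: the limit of > 20000 nM in this assay, at which 2 of the 4 values shown sit.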